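The compounds below may be only part of what the source reports. "The series", "measured", "known", "first", "only" and "open" are said of these compounds alone.

In an ADME assay on Li23 cells (Homo sapiens) for cytotoxicity, read by WST assay (a higher number here means that more compound is tolerated, a lower number that less compound is tolerated), three compounds on two related cores have been measured so far. Compound 1 `CCCC(=O)N(C)c1ccc(C(O)(C(F)(F)F)C(F)(F)F)cc1` is the shortest-chain amide of the first core. In this assay compound 1 gives > 100000 nM, which is a limit of the assay rather than a number, namely (the limit of > 100000 nM in this assay, at which 1 of the 3 values shown sits). Compound 2 `CCCCC(=O)N(C)c1ccc(C(O)(C(F)(F)F)C(F)(F)F)cc1` differs from compound 1 by methyl in place of hydrogen on a saturated chain carbon, three bonds along the chain from a carbonyl carbon. In this assay compound 2 gives 26000 nM, and the change produced an at least 3.8-fold lower number from compound 1 to compound 2 (0.58 log units; beyond the scatter). Compound 3 `CCN(C(=O)c1ccccc1)c1ccc(C(O)(C(F)(F)F)C(F)(F)F)cc1` belongs to the second core; how that core differs from the core of compound 1 is not broken down here. In this assay compound 3 gives 19000 nM, a value within the scatter of that of compound 2.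

Compound 4 `CCCN(C(=O)c1ccccc1)c1ccc(C(O)(C(F)(F)F)C(F)(F)F)cc1` has not yet been measured in this assay. It differs from compound 3 by methyl in place of hydrogen on a saturated chain carbon, two bonds along the chain from an amide-type nitrogen. Within the data shown here, this is the same kind of change as the one from compound 1 to compound 2, though the place is not identical: there the methyl enters three bonds along the chain from a carbonyl carbon, here two bonds along the chain from an amide-type nitrogen. The author expects a downward step, resting on the earlier at least 3.8-fold lower number from compound 1 to compound 2 (0.58 log units; beyond the scatter), but a smaller one, since compound 3 already starts well under the limit; the expected step is a 1.9-fold lower number from compound 3 to compound 4 (0.28 log units; within the scatter). Compound 4 is estimated in this assay at 10000 nM, with an expected range from 4000 nM to 30000 nM.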

Compound 4, half-maximal cytotoxic concentration: 15000 nM
Compound 4: the middle estimate sits 1.5-fold (0.18 log units) below what was measured; low and high end bracket the measured number.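

In this assay the new step is a 1.3-fold lower number from compound 3 to compound 4 (0.10 log units; within the scatter), so the added methyl has no readable effect on this core, and the change does not carry over from the other core with the same size: the same change on two cores in this assay, an at least 3.8-fold lower number (0.58 log units; beyond the scatter) from compound 1 to compound 2 and a 1.3-fold lower number (0.10 log units; within the scatter) from compound 3 to compound 4, at least 3.0-fold (0.48 log units) apart, beyond the scatter of two such steps The earlier step starts from a limit of the assay and not from a number, so its true size stays unknown, and the gap between the two steps is known only as a lower bound: the limit of > 100000 nM in this assay, at which 1 of the 4 values shown sits. With one pair on each core, the result does not show why the steps differ, since the cores differ and so do the places, three bonds along the chain from a carbonyl carbon in one pair and two bonds along the chain from an amide-type nitrogen in the other.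

The compounds shown leave open whether a longer chain, or an amine or a carboxylic acid in place of the entering methyl, would move the number beyond the scatter on the core of compound 3. They also leave open how the same methyl would behave at one identical place on both cores, which is the comparison that would separate the effect of the core from that of the place.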